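The source may report more compounds than this note shows. Statements on the series, on what has been measured and on what is new or still open speak of the compounds shown alone.

For the measured compounds named here, in a functional assay on MOLT-4 cells (Homo sapiens) for inhibition (a higher number here means a weaker inhibitor, a lower number a stronger inhibitor), only two compounds have been measured so far. There, compound 1 (`CN(C)c1ccc(/C=C2\CCc3ccccc3C2=O)cc1`) gives 2110 nM and compound 2 (`O=C1CCCCC/C1=C\c1cccc(F)c1`) gives 482000 nM as the higher of the two numbers, which makes compound 2 the weaker inhibitor of the pair by a margin beyond the scatter. Compound 3 (`O=C1CCCCC/C1=C\c1cccc(Br)c1`) carries a single change from compound 2, bromo in place of fluoro on an aromatic carbon, and it has yet to be measured. Going by the values given here, no measured pair shows what such a swap does in this assay, so the expectation is cautious: a small step towards a lower number, one that may not clear the scatter. The estimated move is a 1.9-fold lower number from compound 2 to compound 3 (0.29 log units; within the scatter) in this case. The expected value for compound 3 is 250000 nM with an estimated range from 70000 nM to 700000 nM around it.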

Compound 3, half-maximal inhibitory concentration: 176000 nM
Compound 3: the middle estimate sits 1.4-fold (0.15 log units) above what was measured; the measured number falls inside the stated range.
By their numbers in this assay, from the lowest: compound 1; then compound 3; then compound 2.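

For the compounds shown here, this is the first pair measured that differs in one place only, so this assay now gives a direct reading of the swap. Bromo in place of fluoro, on an aromatic carbon meta to a group of 9 heavy atoms, gives a 2.7-fold lower number from compound 2 to compound 3 (0.44 log units; beyond the scatter) and so a modestly stronger inhibitor, which shows that the assay responds to a change of halogen at this position, if only by a modest step. No measurement at hand explains this step.

From the compounds shown here alone, with only two halogens compared here, it remains open whether chloro, a methoxy group or an amine at the same position would give a lower or a higher number. Going by these compounds, it is also open whether the same swap would have a similar effect on a different core, such as the core of compound 1.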